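The source may hold more compounds than are shown below. What is called first, only, known or untested is meant among the compounds shown, and "the series" means these compounds.

Of the compounds shown here, three that share one core have been tested in a functional assay on HCT-116 cells (Homo sapiens) for inhibition, read by sulforhodamine B assay, with a stated time of 48 h, tested at 50 uM; on this read-out higher numbers stand for more inhibition of growth at the one concentration tested and lower numbers for less inhibition of growth. Compound 1 `COc1cc2c(cc1CC=C(C)C)C(=O)C[C@@H](c1ccc(Oc3ccccc3)cc1)O2` carries a phenoxy group on its pendant ring; in this assay compound 1 gives 76%, the highest of the three numbers here. Compound 2 `COc1ccc([C@@H]2C/C(=N/OCc3cn(-c4ccc(C(=O)c5ccccc5)cc4)nn3)c3cc(CC=C(C)C)c(OC)cc3O2)cc1` differs from compound 1 both on the pendant ring and elsewhere in the core, and in this assay compound 2 gives 52%, a number beyond the scatter below compound 1. Compound 3 `COc1ccc([C@@H]2C/C(=N/O)c3cc(CC=C(C)C)c(OC)cc3O2)cc1` also changes the core, and in this assay compound 3 gives 47%, furthest from compound 1. The numbers of compounds 2 and 3 lie within the scatter of each other and cannot be told apart.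

Compound 4 `CCCCOc1ccc([C@@H]2CC(=O)c3cc(CC=C(C)C)c(OC)cc3O2)cc1` is not yet measured. It keeps the carbonyl of compound 1 and differs from it in one place only: butyl in place of phenyl on an oxygen on an aromatic ring. Among the measured compounds shown here, no measured pair here shows what this change does, so the expectation rests on compound 1 alone, which gives 76%. A small loss is expected, a number 10 percentage points lower from compound 1 to compound 4 (within the scatter), most likely within the scatter. Compound 4 is therefore expected to give about 66% in this assay, with a range from 45% to 85%.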

Compound 4, percent growth inhibition at one concentration: 60%
Beside the measured number, compound 4's estimate is 6 percentage points above it; low and high end bracket the measured number.
By their numbers in this assay, from the lowest: compounds 3, 2 and 4 (each within the scatter of the next, the first and the last beyond it); then compound 1.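

Among the compounds shown here, this is the only pair so far that differs in one place, so the effect of the group on an oxygen on an aromatic ring can now be read on its own. In this assay, going from phenoxy to butoxy gives a number 16 percentage points lower from compound 1 to compound 4 (beyond the scatter), which shows that this position does register the change: an open butyl chain in place of the phenyl ring leaves clear growth inhibition at the one concentration tested, but a modest amount less of it. No measurement at hand explains why the step has this size.

The compounds shown leave open how the number would respond to a longer chain such as hexyl, to a benzyl group, or to an amine at the end of the butyl chain on the same oxygen, so one step gives a single point and no trend. They also leave open whether the same exchange would give a step of similar size on the oxime form of the core carried by compound 3.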